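The source may report more compounds than this note shows. Statements on the series, on what has been measured and on what is new or still open speak of the compounds shown alone.

Measured compounds:
- compound 1, `CCO/N=C/Nc1cc(Cl)c(OCC#N)c(Cl)c1`: 3.1
- compound 2, `C#CCc1c(Cl)cc(N/C=N/OC(C)C)cc1Cl`: 3.9

Both were run in a physicochemical assay for lipophilicity, measured as octanol-water partition; a lower number here means a more polar compound, a higher number a more lipophilic compound. Compound 1 gives 3.1. Compound 2 gives 3.9, the higher of the two numbers; compound 1 sits a distance below that is beyond the scatter of the method. Within the data shown here, no step between a single-change pair is available here, so the two values are simply read as they stand.

Compound 3, `C#CCc1c(Cl)cc(N/C=N/Oc2ccc(C)cc2)cc1Cl`, has not yet been measured in this assay. It differs from compound 2 in one place: 4-methylphenyl in place of isopropyl on an oxygen. The group that leaves is small and saturated; the group that enters is larger and carries an aromatic ring. A step upward in this assay is expected, clearly beyond the scatter, of roughly a number 1.20 log units higher from compound 2 to compound 3 (beyond the scatter).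

Compound 3 is estimated at 5.1 in this assay, with a range of 4.5 to 5.7.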

Compound 3, partition coefficient: 4.8
For compound 3 the middle estimate is 0.30 log units above the measured one; the range from low to high includes it.
By their numbers in this assay, from the lowest: compound 1; then compound 2; then compound 3.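

Among these compounds, the only single-change pair sits on an oxygen whose other neighbours are: double-bonded nitrogen. In this assay, 4-methylphenyl in place of isopropyl gives a number 0.90 log units higher from compound 2 to compound 3 (beyond the scatter), so this position responds to the exchange of a small saturated group for a larger one carrying a six-membered aromatic ring of carbon only. No measurement on hand accounts for the size of this step.

A single step cannot separate the contribution of the aromatic ring from that of the added carbon atoms, and a longer saturated chain such as n-hexyl on the same oxygen would bear on that question. From the compounds shown here alone, how this assay responds to an amine or a carboxylic acid at this position also remains open.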